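The source may hold more compounds than are shown below. What is called first, only, known or untested is meant among the compounds shown, and "the series" means these compounds.

Going by the values given here, compound 2 `O=C(O)c1csc(SCCN2C(=O)CC[C@@H]2/C=C/[C@@H](O)Cc2cccc(-c3nc4ccccc4o3)c2)n1` is the stronger of the two measured members: in an assay on CHO cells for displacement of a labelled ligand from prostaglandin E2 receptor EP4 subtype (Mus musculus), read by scintillation counting, with a stated time of 60 min (a lower number here means a stronger inhibitor, a higher number a weaker inhibitor), compound 2 gives 0.12 nM, the lowest of the two numbers. Among the compounds with values here, the nearest measured neighbour is compound 1 `O=C(O)c1csc(SCCN2C(=O)CC[C@@H]2/C=C/[C@@H](O)Cc2cccc(-c3ccc(Cl)cc3)c2)n1`, which in this assay gives 0.81 nM; the single measured step, a 6.8-fold lower number from compound 1 to compound 2 (0.83 log units; beyond the scatter), comes from 1,3-benzoxazol-2-yl in place of 4-chlorophenyl on an aromatic carbon.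

Compound 3 `Cc1cccc2oc(-c3cccc(C[C@H](O)/C=C/[C@H]4CCC(=O)N4CCSc4nc(C(=O)O)cs4)c3)nc12` differs from compound 2 by methyl in place of hydrogen on an aromatic carbon, that is, 1,3-benzoxazol-2-yl to 4-methyl-1,3-benzoxazol-2-yl. Within the data shown here, no measured step touches a substituent on the benzoxazole ring; the only step known, a 6.8-fold lower number from compound 1 to compound 2 (0.83 log units; beyond the scatter), concerns exchange of the whole aryl group and does not bear directly on a methyl added to it. The added methyl is small, so the expectation is no change beyond the scatter. The expected step is no change at the digits printed from compound 2 to compound 3 (within the scatter). Compound 3 is therefore estimated at 0.12 nM, with a range from 0.04 nM to 0.4 nM.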

Compound 3, inhibition constant: 0.21 nM
For compound 3 the middle estimate is 1.8-fold (0.24 log units) below the measured one; the measured number falls inside the stated range.
By their numbers in this assay, from the lowest: compounds 2 and 3 (each within the scatter of the next); then compound 1.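

With this assay, the first substituent seen on the benzoxazole ring gives a 1.8-fold higher number from compound 2 to compound 3 (0.24 log units; within the scatter), so this aromatic carbon, ortho to a fused ring, accepts a methyl in place of hydrogen without a change beyond the scatter. The 4-methyl-1,3-benzoxazol-2-yl group also keeps an edge over 4-chlorophenyl, with a 3.9-fold lower number from compound 1 to compound 3 (0.59 log units; beyond the scatter), so the gain from exchanging the whole aryl group survives this added methyl. No supporting data bear on the cause of either step.

Still open, on these data alone, is whether this carbon accepts anything larger or of another kind than methyl, such as methoxy, trifluoromethyl or a longer chain. Also open, as far as these compounds go, is whether methyl on the other carbons of the same six-membered ring gives a similar result.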